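A few compounds are considered here, and "the series" means these few. Any claim that something is new, unique, unknown or untested is made for them only; others in the source may bear on it.

Compound 2 `CC1=C(C(=O)OCc2ccccc2)C(c2ccc(-c3ccccc3)cc2)N(CCCCCC(=O)O)C(=S)N1` stands without a number in a toxicity assay on MCF7 cells (Homo sapiens) for inhibition, with a stated time of 48 h; on this read-out lower numbers stand for stronger inhibition of growth and higher numbers for weaker inhibition of growth: its entry in this assay reads "not determined" (no result reported), so its place among the measured compounds cannot be told. Two related compounds do carry values. Compound 1 `CC1=C(C(=O)OCc2ccccc2)C(c2ccc(-c3ccccc3)cc2)NC(=O)N1Cc1ccc(-c2nnn[nH]2)cc1` gives 160000 nM in this assay, and compound 3 `CC1=C(C(=O)OCc2ccccc2)C(c2ccc(-c3ccccc3C)cc2)NC(=O)N1CCCCCc1nnn[nH]1` gives 72000 nM. The step from compound 2 to compound 4 `CC1=C(C(=O)OCc2ccccc2)C(c2ccc(-c3ccccc3)cc2)N(Cc2ccc(-c3nnn[nH]3)cc2)C(=S)N1` is 4-(1H-tetrazol-5-yl)phenyl in place of 4-carboxybutyl on a saturated chain carbon bound to an amide-type nitrogen in a ring. Since compound 2 has no value, no step size can be computed in this assay; compound 4 shares its substituent pattern with compound 1, so its reading is expected to lie near the weak inhibition shown by compound 1 and compound 3. Compound 4 is therefore estimated at 110000 nM, with a range from 30000 nM to 400000 nM.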

Compound 4, concentration for 50% growth inhibition: 110000 nM
For compound 4 middle estimate and measured number coincide at the digits printed, and the stated range covers the measured number.
By their numbers in this assay, from the lowest: compounds 3, 4 and 1 (each within the scatter of the next, the first and the last beyond it).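

In this assay, among the compounds shown here, compound 2 has no number, so no step to compound 4 can be read. What replacing 4-carboxybutyl with 4-(1H-tetrazol-5-yl)phenyl does to growth inhibition stays open, and nothing shown offers an explanation for the reading of compound 4.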